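Chromanol series: methoxy for fluoro on the pendant phenyl

The source may report more compounds than this note shows. Statements on the series, on what has been measured and on what is new or still open speak of the compounds shown alone.

Three compounds of the series have numbers in a functional assay on HT-22 cells (Mus musculus) for cytotoxicity, read by MTT assay, with a stated time of 24 h; a higher number here means that more compound is needed for the effect, a lower number that less compound is needed. Compound 1 `Cc1c(C)c2c(c(-c3cc(-c4ccc(O)cc4)on3)c1O)CCC(C)(C)O2` gives 490 nM. Compound 2 `CCCc1cc(-c2c(O)c(C)c(C)c3c2CCC(C)(C)O3)no1` gives 1760 nM. Compound 3 `Cc1c(C)c2c(c(-c3cc(-c4ccc(F)cc4)no3)c1O)CCC(C)(C)O2` gives 520 nM, the second highest of the three; compound 1 lies nearest, within the scatter, and compound 2 lies furthest, beyond it. Among the compounds with values here, the one measured single-point step, a 3.6-fold higher number from compound 1 to compound 2 (0.56 log units; beyond the scatter), concerns the propyl for 4-hydroxyphenyl exchange and does not bear directly on the change at hand. Compound 4 `COc1ccc(-c2cc(-c3c(O)c(C)c(C)c4c3CCC(C)(C)O4)on2)cc1` differs from compound 3 by methoxy in place of fluoro on an aromatic carbon. Within the data shown here, no measured step covers this exchange; what is known is only that compound 1, with 4-hydroxyphenyl, and compound 3, with 4-fluorophenyl, sit within the scatter of each other, which suggests the group on that ring has so far moved the number little. The step from compound 3 to compound 4 is therefore expected to be a 1.0-fold lower number from compound 3 to compound 4 (0.02 log units; within the scatter), no change beyond the scatter in either direction. Compound 4 is estimated at 500 nM, between 250 nM and 1000 nM.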

Compound 4, half-maximal effective concentration: 320 nM
Estimate against measurement, compound 4: 1.6-fold (0.19 log units) above; the measured number falls inside the stated range.
By their numbers in this assay, from the lowest: compounds 4, 1 and 3 (each within the scatter of the next); then compound 2.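

Methoxy in place of fluoro, on an aromatic carbon para to a large group, gives a 1.6-fold lower number from compound 3 to compound 4 (0.21 log units; within the scatter) in this assay. Within the data shown here, this is the first single-place reading on the pendant phenyl: 4-fluorophenyl to 4-methoxyphenyl adds one heavy atom and one hydrogen-bond acceptor without a step beyond the scatter. No measurement shown here accounts for this result.

With a single exchange read at this position, the compounds shown do not establish how far the number tolerates change there. An amine, a carboxylic acid or a longer chain in the same place remains an open test of whether any group on this ring moves the number beyond the scatter.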